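Trimming the Methoxy from the Side Chain of Compound 2

The source may report more compounds than this note shows. Statements on the series, on what has been measured and on what is new or still open speak of the compounds shown alone.

Of the compounds shown here, three on a shared core have been measured in a functional assay on MV4-11 cells (Homo sapiens) for inhibition, read by resazurin assay, with a stated time of 72 h; on this read-out higher numbers stand for weaker inhibition of growth and lower numbers for stronger inhibition of growth. Compound 1 `CCSc1nc(C)c(-c2ccnc(Nc3ccc(OC)cc3OC)n2)s1` gives 32400 nM. Compound 2 `COCCOc1nc(C)c(-c2ccnc(Nc3ccc(OC)cc3OC)n2)s1` gives 1980 nM, and compound 3 `COc1ccc(Nc2nccc(-c3cn(C(C)C)c4ccccc34)n2)c(OC)c1` gives 3250 nM. Compound 2 thus shows the lowest of the three numbers, but its gap to compound 3 lies within the scatter, so those two cannot be ordered; only compound 1 is clearly separated, by a 16-fold lower number from compound 1 to compound 2 (1.21 log units; beyond the scatter), the change there being 2-methoxyethoxy in place of ethylsulfanyl.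

Compound 4 `CCOc1nc(C)c(-c2ccnc(Nc3ccc(OC)cc3OC)n2)s1` differs from compound 2 by hydrogen in place of methoxy on a saturated chain carbon, two bonds along the chain from an oxygen on an aromatic ring, so that 2-methoxyethoxy becomes ethoxy. For the measured compounds named here, no measured step isolates this change: the step from compound 1 to compound 2 replaced the whole ethylsulfanyl group at once, and it does not tell how much of its large drop belongs to the methoxy at the chain end. Compound 4 is therefore expected at 4500 nM, within a range from 1500 nM to 14000 nM. That estimate means a step of a 2.3-fold higher number from compound 2 to compound 4 (0.36 log units; beyond the scatter) from compound 2 to compound 4, expected to lie at or just beyond the edge of the scatter.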

Compound 4, concentration for 50% growth inhibition: 3890 nM
Estimate against measurement, compound 4: 1.2-fold (0.06 log units) above, and the stated range covers the measured number.
By their numbers in this assay, from the lowest: compounds 2, 3 and 4 (each within the scatter of the next); then compound 1.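

In this assay, dropping the methoxy from the chain end gives a 2.0-fold higher number from compound 2 to compound 4 (0.29 log units; within the scatter), so the end of the 2-methoxyethoxy chain, at this place on a saturated chain carbon, can lose that methoxy without a change beyond the scatter. The swap of ethylsulfanyl for plain ethoxy alone gives an 8.3-fold lower number from compound 1 to compound 4 (0.92 log units; beyond the scatter), which lies beyond the scatter, so most of the earlier drop of a 16-fold lower number from compound 1 to compound 2 (1.21 log units; beyond the scatter) goes with leaving ethylsulfanyl rather than with the methoxy. Nothing given here explains either step.

From the compounds shown here alone, whether a terminal amine or a carboxylic acid in place of the methoxy would shift the number beyond the scatter remains open. So does the effect of a longer chain on that same oxygen.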